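Acetoxymethyl Replaces Ethoxycarbonyl on the Side Chain

A few compounds are considered here, and "the series" means these few. Any claim that something is new, unique, unknown or untested is made for them only; others in the source may bear on it.

In a functional assay on B16 cells (Mus musculus) for cytotoxicity, read by MTT assay, with a stated time of 48 h (on this read-out lower numbers stand for stronger inhibition and higher numbers for weaker inhibition), compound 1 (`CCOC(=O)Cn1cc(C(=O)Nc2cccc(-c3cn(Cc4ccccc4)nn3)c2)nn1`) gives 20400 nM. Compound 2 (`CCOC(=O)Cn1cc(C(=O)Nc2cccc(-c3cn(CC(=O)OCC)nn3)c2)nn1`) is reported only as a limit, > 100000 nM, so it has no exact number in this assay. Ethoxycarbonyl in place of phenyl on a saturated chain carbon bound to an aromatic nitrogen accounts for an at least 4.9-fold higher number from compound 1 to compound 2 (0.69 log units; beyond the scatter). Compound 3 (`CCOC(=O)Cn1cc(C(=O)Nc2cccc(-c3cn(CCOC(C)=O)nn3)c2)nn1`) has the same atoms as compound 2, joined differently: acetoxymethyl in place of ethoxycarbonyl on a saturated chain carbon bound to an aromatic nitrogen. Acetoxymethyl thus takes the place of ethoxycarbonyl, turning (ethoxycarbonyl)methyl into 2-acetoxyethyl. Among the measured compounds shown here, the only measured step bearing on this change is the one above, and it involved phenyl rather than this exchange. The entering and leaving groups match in every count, so no step beyond the scatter is expected in this assay. The estimated change is a number no higher from compound 2 to compound 3 (the limit leaves the size open). For compound 3 the estimated value is 100000 nM, with an expected range of 40000 nM to 250000 nM.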

Compound 3, half-maximal inhibitory concentration: > 100000 nM
Compound 3 ended at the assay's limit; the forecaster's own chance of this, stated with the estimate: 65%; the middle value sits exactly at the limit.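

In this assay compound 3 gives > 100000 nM, which is a limit of the assay and not a number. Turning (ethoxycarbonyl)methyl into 2-acetoxyethyl therefore yields no readable value, and the step between compound 2 and compound 3 cannot be read: the limit of > 100000 nM in this assay, at which 2 of the 3 values shown sit. Acetoxymethyl in place of phenyl on the saturated chain carbon bound to an aromatic nitrogen gives an at least 4.9-fold higher number from compound 1 to compound 3 (0.69 log units; beyond the scatter), so a second side chain without phenyl now stands beyond the scatter from compound 1.

On these data alone, how far compound 2 and compound 3 lie past the limit, and whether they differ from each other, remains open. The compounds shown also do not tell how an amine or a carboxylic acid at this place would read, or whether any group other than phenyl gives a measurable value there.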